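The source may hold more compounds than are shown below. What is called first, only, known or untested is meant among the compounds shown, and "the series" means these compounds.

In a functional assay on CHO cells for agonist activity at Free fatty acid receptor 1 (Homo sapiens) (a higher number here means that more compound is needed for the effect, a lower number that less compound is needed), three compounds sharing one core have been measured. Compound 1 `Cc1nc(-c2ccc(C(F)(F)F)cc2)sc1CNc1ccc(CCC(=O)O)cc1` gives 67.6 nM. Compound 2 `Cc1nc(-c2ccc(C(F)(F)F)cc2)sc1CNc1ccc(CC(C)C(=O)O)cc1` gives 355 nM, and the step of a 5.3-fold higher number from compound 1 to compound 2 (0.72 log units; beyond the scatter) shows how the branch on the chain shifts the number. Compound 3 `Cc1nc(-c2ccc(C(F)(F)F)cc2)sc1CNc1ccc(CCC(N)=O)cc1` gives 12.9 nM, the lowest of the three: its nearest neighbour is reached by a 5.2-fold lower number from compound 1 to compound 3 (0.72 log units; beyond the scatter), and its furthest by a 28-fold lower number from compound 2 to compound 3 (1.44 log units; beyond the scatter).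

Compound 4 `Cc1nc(-c2ccc(C(F)(F)F)cc2)sc1CNc1ccc(CCC(=O)NC(C)C)cc1` differs from compound 3 by isopropyl in place of hydrogen on an amide-type nitrogen. Within the data shown here, no measured step alters the amide-type nitrogen itself; the only change at the chain end, a 5.2-fold lower number from compound 1 to compound 3 (0.72 log units; beyond the scatter), swaps the whole group and so bears on the question only loosely. The two steps on the chain were modest to large, but neither says what substitution on the amide-type nitrogen does. A step of modest size is therefore expected for compound 4 in this assay, with the direction uncertain and a slight lean toward a higher number, as a 1.9-fold higher number from compound 3 to compound 4 (0.29 log units; within the scatter). Compound 4 is estimated at 25 nM, within 8 nM to 80 nM.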

Compound 4, half-maximal effective concentration: 100 nM
For compound 4 the middle estimate is 4.0-fold (0.60 log units) below the measured one; measured number outside the range, above it.
By their numbers in this assay, from the lowest: compound 3; then compounds 1 and 4 (each within the scatter of the next); then compound 2.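

In this assay the amide-type nitrogen proves to be a place where the number responds strongly: isopropyl in place of hydrogen there gives a 7.8-fold higher number from compound 3 to compound 4 (0.89 log units; beyond the scatter) and so removes the advantage that the unsubstituted amide held over the acid. The isopropylamino end and the hydroxy of the acid cannot be told apart, with a 1.5-fold higher number from compound 1 to compound 4 (0.17 log units; within the scatter) as the step between them, while the (isopropylcarbamoyl)methyl chain end still keeps its distance from the 1-carboxyethyl end of the branched acid, with a 3.6-fold lower number from compound 2 to compound 4 (0.55 log units; beyond the scatter) as the step. Nothing in the data shown accounts for these shifts.

Whether a single methyl on this nitrogen already raises the number remains open, since isopropyl is the only substituent shown there. Equally open, going by these compounds, is how a cyclopropyl or a tert-butyl group, or a second methyl on the same nitrogen, would compare.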